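This account rests on a few compounds, and the source may have more. Where it says the series, first, only, none or still open, it means among the compounds named here.

In an assay on cells for inhibition of high affinity 3',5'-cyclic-AMP phosphodiesterase 7A (Homo sapiens), read by scintillation counting and cAMP accumulation, with a stated time of 30 min (a higher number here means a weaker inhibitor, a lower number a stronger inhibitor), three compounds that share one core have been measured. Compound 1 `CCn1c(NC(C)(C)C)nc2ccsc2c1=O` carries a tert-butylamino group and no aromatic ring beyond the core; in this assay compound 1 gives 1500 nM. Compound 3 `CCn1c(N[C@H]2CC[C@H](C(=O)OC)CC2)nc2ccsc2c1=O` carries instead an amino group bearing a cyclohexyl ring with a methyl ester, again with no further aromatic ring; in this assay compound 3 gives 2100 nM. Compound 2 `CCn1c(NC(C)C)nc2c(-c3cncnc3)csc2c1=O` has an isopropylamino group and a pyrimidin-5-yl group on the core; in this assay compound 2 gives 7.6 nM, the lowest of the three numbers, and its distance to both compound 1 and compound 3 lies well beyond the usual scatter, so compound 2 is the strongest inhibitor of the three.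

Compound 4 `CCn1c(NC(C)C)nc2c(-c3ccco3)csc2c1=O` differs from compound 2 in one place: furan-2-yl in place of pyrimidin-5-yl on an aromatic carbon. Going by the values given here, no measured pair shows this swap, so its effect can only be estimated. Compound 4 keeps an aromatic ring at that place, which compound 1 and compound 3 lack. The step of a 3.9-fold higher number from compound 2 to compound 4 (0.60 log units; beyond the scatter) is expected to be a moderate rise in the number, beyond the scatter. Compound 4 is therefore estimated at 30 nM, with a likely range from 6 nM to 150 nM.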

Compound 4, half-maximal inhibitory concentration: 12 nM
Beside the measured number, compound 4's estimate is 2.5-fold (0.40 log units) above it, within the range that was stated.
By their numbers in this assay, from the lowest: compounds 2 and 4 (each within the scatter of the next); then compounds 1 and 3 (each within the scatter of the next).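

In this assay placing furan-2-yl in place of pyrimidin-5-yl on this aromatic carbon gives a 1.6-fold higher number from compound 2 to compound 4 (0.20 log units; within the scatter) and so leaves the two compounds indistinguishable. The ring at this place can therefore go from 6 heavy atoms and 2 hydrogen-bond acceptors to 5 heavy atoms and 1 hydrogen-bond acceptor, with the ring nitrogens replaced by an oxygen, without a difference that can be read in this measurement. Nothing available explains why these two rings give readings so close together.

On these data alone, whether having an aromatic ring at this place matters at all stays open, since compound 1 and compound 3 lack one but also carry different amino groups, so neither differs from compound 2 or compound 4 in one place only. A compound with the isopropylamino group and only hydrogen at this place would test that directly, while a phenyl ring, with no hetero atom, or a pyridine ring would show whether the ring's hetero atoms have any bearing on the number.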